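Lengthening the amine chain on a spirocyclic amide core

A few compounds are considered here, and "the series" means these few. Any claim that something is new, unique, unknown or untested is made for them only; others in the source may bear on it.

Measured so far:
compound 1 `CC(C)(C)c1ccc(C(=O)N2CCC3(CC2)C(=O)N(CC(=O)NCCN)CN3c2ccccc2)cc1` — 7000 nM
compound 2 `CS(=O)(=O)NCCNC(=O)CN1CN(c2ccccc2)C2(CCN(C(=O)c3ccc(C4CCCCC4)cc3)CC2)C1=O` — 2100 nM
compound 3 `CS(=O)(=O)N1CCN(C(=O)CN2CN(c3ccccc3)C3(CCN(C(=O)c4ccc(C5CCCCC5)cc4)CC3)C2=O)CC1` — 6300 nM

In an assay on HEK293 cells for displacement of a labelled ligand from NPC1-like intracellular cholesterol transporter 1 (Homo sapiens) (a lower number here means a stronger inhibitor, a higher number a weaker inhibitor), compound 1 gives the highest of the three numbers; its value sits within the scatter of compound 3 and beyond it from compound 2. Compound 4 `CC(C)(C)c1ccc(C(=O)N2CCC3(CC2)C(=O)N(CC(=O)NCCCCN)CN3c2ccccc2)cc1` differs from compound 1 by 2-aminoethyl in place of amino on a saturated chain carbon, two bonds along the chain from an amide-type nitrogen. Within the data shown here, the only measured step, a 3.0-fold higher number from compound 2 to compound 3 (0.48 log units; beyond the scatter), concerns a different part of the molecule and does not bear on this chain extension, so no measured step directly informs it. Without such a precedent, no step beyond the scatter is expected, and compound 4 is estimated at 6000 nM (range 2500 nM to 15000 nM), corresponding to an expected 1.2-fold lower number from compound 1 to compound 4 (0.07 log units; within the scatter).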

Compound 4, half-maximal inhibitory concentration: 14500 nM
Beside the measured number, compound 4's estimate is 2.4-fold (0.38 log units) below it, within the range that was stated.
By their numbers in this assay, from the lowest: compound 2; then compounds 3 and 1 (each within the scatter of the next); then compound 4.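

In this assay, 2-aminoethyl in place of amino, on a saturated chain carbon, two bonds along the chain from an amide-type nitrogen, gives a 2.1-fold higher number from compound 1 to compound 4 (0.32 log units; beyond the scatter). This shows that the position is sensitive to chain length, with the longer chain here giving the weaker inhibitor, though the step is modest. Nothing available accounts for this shift. With only two chain lengths shown, no trend can be drawn. As far as these compounds go, it remains open whether a still longer chain would continue the shift, or whether a hydroxyl or carboxylic acid in place of the terminal amine would be tolerated.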